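A few compounds are considered here, and "the series" means these few. Any claim that something is new, unique, unknown or untested is made for them only; others in the source may bear on it.

Values in a functional assay on RS4-11 cells (Homo sapiens) for inhibition, read by CCK-8 assay, with a stated time of 48 h; on this read-out lower numbers stand for stronger inhibition and higher numbers for weaker inhibition:
- compound 1 `COc1ccc(S(=O)(=O)Oc2ccccc2/C=C(\C#N)C(=O)Nc2nnc(Cc3ccccc3)s2)cc1`: 1060 nM
- compound 2 `COc1ccc(S(=O)(=O)Oc2ccccc2/C=C(\C#N)C(=O)Nc2nnc(Cc3ccc(F)cc3)s2)cc1`: 1210 nM
- compound 3 `COc1ccc(S(=O)(=O)Oc2ccccc2/C=C(\C#N)C(=O)Nc2nnc(Cc3cccc(F)c3)s2)cc1`: 1210 nM

Compound 3, at 1210 nM, is level with compound 2 at the digits given and lies within the scatter of compound 1. All three values therefore sit in a single narrow band.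

The next change leads to compound 4 `COc1ccc(S(=O)(=O)Oc2ccccc2/C=C(\C#N)C(=O)Nc2nnc(Cc3ccc(C)cc3)s2)cc1`: 4-methylphenyl in place of 3-fluorophenyl on a saturated chain carbon bound to an aromatic carbon. In words, 4-methylphenyl replaces 3-fluorophenyl on a saturated chain carbon bound to an aromatic carbon.

Among the compounds with values here, three measured steps bear on this change. Fluoro in place of hydrogen gives a 1.1-fold higher number from compound 1 to compound 2 (0.06 log units; within the scatter) and a 1.1-fold higher number from compound 1 to compound 3 (0.06 log units; within the scatter), while moving from 4-fluorophenyl to 3-fluorophenyl gives no change at the digits printed from compound 2 to compound 3 (within the scatter). None of these exceeds the scatter, so the ring of this group has so far tolerated every change tried, although only fluoro has been tested on it. Within the data shown here, no compound with a methyl on this ring has been measured, so the expectation is an extrapolation and the range is kept wider than the spread of the three values.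

No step beyond the scatter is expected in this assay, and no direction is favoured with any confidence. The estimate is a 1.1-fold lower number from compound 3 to compound 4 (0.04 log units; within the scatter). For compound 4 the expected value is 1100 nM, with an estimated range of 650 nM to 1900 nM.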

Compound 4, half-maximal inhibitory concentration: 1010 nM
Estimate against measurement, compound 4: 1.1-fold (0.04 log units) above; measured number inside the range.
By their numbers in this assay, from the lowest: compounds 4, 1, 2 and 3 (each within the scatter of the next).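

In this assay a methyl on this ring, the first group other than fluoro at this place, stays within the scatter by every route that can be read: a 1.2-fold lower number from compound 3 to compound 4 (0.08 log units; within the scatter), a 1.2-fold lower number from compound 2 to compound 4 (0.08 log units; within the scatter), and a 1.0-fold lower number from compound 1 to compound 4 (0.02 log units; within the scatter). The tolerance seen so far on the ring of the benzyl group therefore no longer rests on fluoro alone, since the change from 3-fluorobenzyl to 4-methylbenzyl, which replaces fluorine with carbon and also changes the ring position of the group, leaves compounds 1 to 4 in one band, with none of the four going against it. No accompanying data bear on why this ring accepts these changes.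

Still open, as far as these compounds go, is whether an amine or a carboxylic acid on this ring, a methoxy group, or a longer chain in place of the saturated chain carbon would keep the number in the same band. The compounds shown also hold the rest of the shared core constant, so they leave open what the nitrile and the methoxy group on the core contribute to this read-out.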